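This account rests on a few compounds, and the source may have more. Where it says the series, first, only, none or still open, it means among the compounds named here.

Compound 2, `COc1cc(-c2nnc(SCc3ccccc3)n2/N=C/c2ccccc2)cc(OC)c1OC`, is the starting point of this step. In a functional assay on MCF7 cells (Homo sapiens) for cytotoxicity, read by MTT assay, with a stated time of 48 h (a higher number here means a weaker inhibitor, a lower number a stronger inhibitor), compound 2 gives > 200000 nM, which is a limit of the assay rather than a number. Its two measured neighbours stand the same way. Compound 1, `COc1cc(-c2nnc(SC)n2/N=C/c2ccccc2)cc(OC)c1OC`, gives in this assay a value of > 200000 nM, again a limit. Compound 3, `COc1cc(-c2nnc(SCc3ccc(F)cc3)n2/N=C/c2ccccc2)cc(OC)c1OC`, gives in this assay a value of > 200000 nM, also a limit. Because all three sit at the limit of > 200000 nM in this assay, at which 3 of the 3 values shown sit, the steps a step that the two limits leave unreadable from compound 1 to compound 2, a step that the two limits leave unreadable from compound 1 to compound 3 and a step that the two limits leave unreadable from compound 2 to compound 3 cannot be read in size or direction.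

Compound 4, `COc1cc(-c2nnc(SCc3ccccc3Cl)n2/N=C/c2ccccc2)cc(OC)c1OC`, differs from compound 2 by chloro in place of hydrogen on an aromatic carbon. The nearest comparison, the step from compound 2 to compound 3, is itself unreadable, so there is no measured guide to how large a step to expect in this assay; the three limits only make another limit the most likely outcome. Compound 4 is therefore expected at about 250000 nM, in a range from 100000 nM to 600000 nM, and the estimated step from compound 2 to compound 4 is a step that the limit leaves unreadable from compound 2 to compound 4.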

Compound 4, half-maximal inhibitory concentration: > 200000 nM
Compound 4: a limit, no number; the forecaster's own chance of this, stated with the estimate: 85%; the middle value lies beyond the limit too.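

Within the data shown here, compound 4 also gives only a limit, so no step between it and compound 1, compound 2 or compound 3 can be read in size or direction: the limit of > 200000 nM in this assay, at which 4 of the 4 values shown sit.

The compounds shown leave open how strongly any of these four acts on these cells, and whether any change among them makes a difference.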